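Nitro for methyl on the sulfonyl aryl: compound 3

The source may hold more compounds than are shown below. What is called first, only, known or untested is meant among the compounds shown, and "the series" means these compounds.

compound 1 `CCC(C)C(C(=O)Nc1ccc(C(C)=O)cc1)N(C(=O)c1ccccc1)S(=O)(=O)c1ccc(C)cc1` 41.1%
compound 2 `CC(=O)c1ccc(NC(=O)C(C(C)C)N(C(=O)c2ccccc2)S(=O)(=O)c2ccc(C)cc2)cc1` 36.6%

In a functional assay for inhibition, read by spectrophotometry, with a stated time of 20 min, tested at 4 mg/mL (a higher number here means a stronger effect of the compound at the concentration tested, a lower number a weaker effect), compound 1 gives 41.1% and compound 2 gives 36.6%; the two numbers lie within the scatter of each other, so compound 1 does not stand apart. Compound 3 `CCC(C)C(C(=O)Nc1ccc(C(C)=O)cc1)N(C(=O)c1ccccc1)S(=O)(=O)c1ccc([N+](=O)[O-])cc1` differs from compound 1 by nitro in place of methyl on an aromatic carbon. Going by the values given here, the only measured step, a number 4.5 percentage points lower from compound 1 to compound 2 (within the scatter), concerns a saturated chain carbon and does not bear on this aromatic change; no step with nitro for methyl has been measured. Compound 3 is therefore expected close to compound 1, with a number 0.1 percentage points lower from compound 1 to compound 3 (within the scatter) expected to stay within the scatter. The estimate for compound 3 is 41%, ranging from 24% to 58%.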

Compound 3, a percentage reported as inhibition, at one concentration (the size of the read-out at that concentration, not a potency): 48.4%
Estimate against measurement, compound 3: 7.4 percentage points below; the measured number falls inside the stated range.
By their numbers in this assay, from the lowest: compounds 2, 1 and 3 (each within the scatter of the next, the first and the last beyond it).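

In this assay, going by these compounds alone, the change from (4-methylphenyl)sulfonyl to (4-nitrophenyl)sulfonyl gives a number 7.3 percentage points higher from compound 1 to compound 3 (within the scatter), the first reading at this aromatic carbon, since the earlier step concerned only a saturated chain carbon. Nitro in place of methyl, with three heavy atoms for one and two hydrogen-bond acceptors entering, therefore leaves the read-out not distinguishable from that of compound 1. Nothing measured here accounts for the result.

As far as these compounds go, whether an amine or a carboxylic acid on this aromatic carbon would move the read-out beyond the scatter stays open. So does whether nitro reads the same on the side chain of compound 2.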